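Halogen swap on the vinyl position of the sulfonyl series

A few compounds are considered here, and "the series" means these few. Any claim that something is new, unique, unknown or untested is made for them only; others in the source may bear on it.

Measured so far:
compound 1, `CCCCCCCC1C=C(Cl)CCN1S(=O)(=O)c1ccc(C)cc1`, 92000 nM
compound 2, `Cc1ccc(S(=O)(=O)N2CCC(Cl)=CC2C2CCCCC2)cc1`, 39000 nM
compound 3, `Cc1ccc(S(=O)(=O)N2CCC(Cl)=CC2c2ccccc2)cc1`, 17000 nM

In a functional assay on A2780 cells (Homo sapiens) for antiproliferative activity, read by sulforhodamine B assay, with a stated time of 48 h (a higher number here means a weaker inhibitor of growth, a lower number a stronger inhibitor of growth), compound 1 gives the highest number of the three measured compounds: compound 2 sits nearest, a 2.4-fold lower number from compound 1 to compound 2 (0.37 log units; beyond the scatter), and compound 3 furthest, a 5.4-fold lower number from compound 1 to compound 3 (0.73 log units; beyond the scatter); between those two, a 2.3-fold lower number from compound 2 to compound 3 (0.36 log units; beyond the scatter). All three steps change the group on the saturated ring carbon and leave the chloro untouched.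

Compound 4, `CCCCCCCC1C=C(Br)CCN1S(=O)(=O)c1ccc(C)cc1`, differs from compound 1 by bromo in place of chloro on a double-bonded ring carbon. Within the data shown here, no measured step touches this position, so nothing here speaks for a shift in this assay beyond the scatter in either direction. The expectation for compound 4 is therefore a number close to that of compound 1, estimated at 80000 nM, range 40000 nM to 160000 nM, a step of a 1.2-fold lower number from compound 1 to compound 4 (0.06 log units; within the scatter).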

Compound 4, concentration for 50% growth inhibition: > 100000 nM
Compound 4 gave a limit, no number; the forecaster's own chance of this, stated with the estimate: 20%; middle value at least 1.2-fold (0.09 log units) from the limit.
By their numbers in this assay, from the lowest: compound 3; then compound 2; then compound 1. At a limit, above all of these: compound 4.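

Compound 4 reads as a limit of the assay, not a number: the limit of > 100000 nM in this assay, at which 1 of the 4 values shown sits. In this assay, as far as these compounds go, the bromo-for-chloro swap on the double-bonded ring carbon gives an at least 1.0-fold higher number from compound 1 to compound 4 (0.03 log units; that floor lies within the scatter), so the size of any shift remains unknown. Among these compounds, this is the first reading at this position, and with the heptyl group kept, bromo brings no lower number.

Open, from the compounds shown here alone, is whether bromo behaves the same alongside the cyclohexyl or phenyl group. Also open, going by these compounds, is how fluoro, an amine or a nitrile would read on this ring carbon.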